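Chain Lengthening in Threonine Amides Against A-431 Cells

The compounds below may be only part of what the source reports. "The series", "measured", "known", "first", "only" and "open" are said of these compounds alone.

Of the compounds shown here, three built on a threonine-derived amide core have been tested, and a fourth awaits testing. Compound 1 `CCCCCCCCNC(=O)[C@@H](NC(=O)c1cccs1)[C@@H](C)O` carries an octyl chain on one amide nitrogen; in a functional assay on A-431 cells (Homo sapiens) for cytotoxicity, read by MTT assay, with a stated time of 48 h (a higher number here means a weaker inhibitor, a lower number a stronger inhibitor), compound 1 gives 32200 nM. Compound 2 `CCCCCCCCCCCCNC(=O)[C@@H](NC(=O)c1cccs1)[C@@H](C)O` differs from it only by butyl in place of hydrogen on a saturated chain carbon, eight bonds along the chain from an amide-type nitrogen. In this assay compound 2 gives 16600 nM, and the result is a 1.9-fold lower number from compound 1 to compound 2 (0.29 log units; within the scatter), so the two cannot be told apart with confidence.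

Compound 3 `CCCCCCCCCCCCCCNC(=O)[C@@H](NC(=O)c1ccccc1)[C@@H](C)O` belongs to a second core, and the difference between the two cores is not broken down here. In this assay compound 3 gives 118000 nM, the highest of the three numbers, beyond the scatter from both compound 1 and compound 2.

Compound 4 `CCCCCCCCCCCCCCCCCCNC(=O)[C@@H](NC(=O)c1ccccc1)[C@@H](C)O` has not yet been measured. It differs from compound 3 by butyl in place of hydrogen on a saturated chain carbon, ten or more bonds along the chain from an amide-type nitrogen. This is the same kind of change as that from compound 1 to compound 2, though not the same: the butyl enters at a different place along the chain. Among the measured compounds shown here, with only one earlier example of this kind of change, and that one within the scatter, the expectation is a step no larger than the earlier one, a 1.6-fold lower number from compound 3 to compound 4 (0.20 log units; within the scatter), because the earlier step was a 1.9-fold lower number from compound 1 to compound 2 (0.29 log units; within the scatter). Compound 4 is therefore estimated at 75000 nM, with a range from 30000 nM to 180000 nM.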

Compound 4, half-maximal inhibitory concentration: 113000 nM
Compound 4: middle estimate off by 1.5-fold (0.18 log units), on the low side; measured number inside the range.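

In this assay, butyl in place of hydrogen on a saturated chain carbon, ten or more bonds along the chain from an amide-type nitrogen, gives a 1.0-fold lower number from compound 3 to compound 4 (0.02 log units; within the scatter), so this pair cannot be told apart with confidence. Set beside the earlier example, the same kind of change reads alike on the two cores: the same change on two cores in this assay, a 1.9-fold lower number (0.29 log units; within the scatter) from compound 1 to compound 2 and a 1.0-fold lower number (0.02 log units; within the scatter) from compound 3 to compound 4, 1.9-fold (0.27 log units) apart, within the scatter of two such steps. Among the compounds shown here, this agreement shows only that neither core gives a step that stands clear of ordinary measurement noise; it does not show that the change has a real effect that carries from one core to the other, nor that it has no effect at all, since there are only two pairs and the butyl enters at a different place along the chain in each.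

The compounds shown leave open how an octyl or dodecyl chain would read on the core of compound 3, which would allow the two cores to be compared directly with the chain held the same. They also leave open whether an amine or a carboxylic acid at the far end of the chain would produce a step beyond the scatter, where simple chain extension has not.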